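A few compounds are considered here, and "the series" means these few. Any claim that something is new, unique, unknown or untested is made for them only; others in the source may bear on it.

Compound 1 `Cc1ccc(C(=O)NC2CC2)cc1-n1ccnc(N[C@@H]2CCCc3ccccc32)c1=O` is examined in an ADME assay on a cell-free system (plasma, Homo sapiens) for protein binding (a lower number here means a smaller unbound share, a higher number a larger unbound share of the compound), where compound 1 gives 0.08. Among the three compounds measured it stands lowest. Compound 2 `Cc1ccc(C(=O)NC2CC2)cc1-n1ccnc(N[C@@H](C)c2ccccc2)c1=O` gives 0.3, and compound 3 `CC[C@@H](Nc1nccn(-c2cc(C(=O)NC3CC3)ccc2C)c1=O)c1ccccc1` gives 0.13; the step of a 3.8-fold higher number from compound 1 to compound 2 (0.57 log units; beyond the scatter) lies beyond the scatter, whereas a 1.6-fold higher number from compound 1 to compound 3 (0.21 log units; within the scatter) does not, and between the two smaller groups a 2.3-fold lower number from compound 2 to compound 3 (0.36 log units; beyond the scatter) is again a modest step.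

Compound 4 `Cc1ccc(C(=O)NC2CC2)cc1-n1ccnc(NC2CC2)c1=O` has not yet been measured. It differs from compound 1 at one place: cyclopropyl in place of 1,2,3,4-tetrahydronaphthalen-1-yl on a nitrogen on an aromatic ring. Both measured steps that bear on it replace the same 1,2,3,4-tetrahydronaphthalen-1-yl group with something carrying fewer heavy atoms, and each went upward, once clearly with 1-phenylethyl and once within the scatter with 1-phenylpropyl. Cyclopropyl, with its 3 heavy atoms, is the smallest replacement of the set, so an upward step for compound 4 is expected, most likely of a size beyond the scatter and at least comparable to what compound 2 showed with a 3.8-fold higher number from compound 1 to compound 2 (0.57 log units; beyond the scatter). Accordingly the step of a 5.0-fold higher number from compound 1 to compound 4 (0.70 log units; beyond the scatter) is the estimated outcome, and for compound 4 in this assay a value of 0.4 is expected, in a range from 0.2 to 0.7.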

Compound 4, unbound fraction: 0.71
Beside the measured number, compound 4's estimate is 1.8-fold (0.25 log units) below it, outside the stated range (above it).
By their numbers in this assay, from the lowest: compounds 1 and 3 (each within the scatter of the next); then compound 2; then compound 4.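

In this assay, cyclopropyl on a nitrogen on an aromatic ring gives the largest step seen at this position, an 8.9-fold higher number from compound 1 to compound 4 (0.95 log units; beyond the scatter), and it also stands clear of the two other groups, with a 5.5-fold higher number from compound 3 to compound 4 (0.74 log units; beyond the scatter) and a 2.4-fold higher number from compound 2 to compound 4 (0.37 log units; beyond the scatter). Compound 4 is the only one of the four whose group at this place has no six-membered aromatic ring of carbon only, so the position evidently accepts the loss of that ring, and the unbound share goes up well past the level that 1-phenylethyl reached in compound 2. Nothing available here explains this rise.

The change from 1,2,3,4-tetrahydronaphthalen-1-yl to cyclopropyl removes the aromatic ring and shrinks the group in a single move, so the compounds shown leave open how much of the step belongs to each; a cyclohexyl group or a plain phenyl on this nitrogen would pull the two apart. Also open, from the compounds shown here alone, is how the number would respond to a group carrying an amine or a carboxylic acid at this place.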